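Lipophilicity notes: oxazolidinone series, compound 2 to compound 4

The source may hold more compounds than are shown below. What is called first, only, known or untested is meant among the compounds shown, and "the series" means these compounds.

The series shares one core. Compound 1 `CN(CCC#N)C[C@H]1CN(c2ccc(-n3cc(-c4ccccn4)cn3)c(F)c2)C(=O)O1` gives 1.9 in a physicochemical assay for lipophilicity, read by HPLC, measured as octanol-water partition; a lower number here means a more polar compound, a higher number a more lipophilic compound. Compound 2 `CCN1CCN(C[C@H]2CN(c3ccc(-n4cc(-c5ccccn5)cn4)c(F)c3)C(=O)O2)CC1` gives 2.19 in this assay, and compound 3 `COC[C@H]1CN(c2ccc(-n3cc(-c4ccccn4)cn3)c(F)c2)C(=O)O1` gives 2.18. Compound 2 stands at the upper end of the three numbers, yet every gap to it lies within the scatter: a number 0.29 log units higher from compound 1 to compound 2 (within the scatter) and a number 0.01 log units lower from compound 2 to compound 3 (within the scatter). Likewise a number 0.28 log units higher from compound 1 to compound 3 (within the scatter).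

Compound 4 `CONC(=O)[C@H]1CN(c2ccc(-n3cc(-c4ccccn4)cn3)c(F)c2)C(=O)O1` has not been measured. Its change from compound 2 is methoxycarbamoyl in place of (4-ethylpiperazin-1-yl)methyl on a saturated ring carbon. Among the measured compounds shown here, of the measured steps, only the step from compound 2 to compound 3 removes the 4-ethylpiperazin-1-yl group, and it was flat. For the measured compounds named here, no measured step brings in a methoxycarbamoyl group, and none moves a substituent from the saturated chain carbon onto the saturated ring carbon, so the basis for compound 4 is thin. Given that three different substituents at this position all landed in a narrow band, compound 4 is expected at 1.8, between 1.3 and 2.3. The expected step from compound 2 is a number 0.39 log units lower from compound 2 to compound 4 (beyond the scatter), at the edge of the scatter.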

Compound 4, partition coefficient: >= 1.58
Compound 4 ended at the assay's limit; the forecaster's own chance of this, stated with the estimate: 2%; the middle value does not contradict the limit.
By their numbers in this assay, from the lowest: compounds 1, 3 and 2 (each within the scatter of the next).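

In this assay compound 4 gives >= 1.58, which is a limit of the assay and not a number. Among the compounds shown here, no step to compound 4 from compound 1, compound 2 or compound 3 can be read. The compounds shown leave open how methoxycarbamoyl on the saturated ring carbon compares with the other three substituents.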